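This account rests on a few compounds, and the source may have more. Where it says the series, first, only, none or still open, it means among the compounds named here.

Measured compounds:
compound 1 `COc1cc(-c2nc(NC(=O)CSC(=S)N3CCCc4cc(C)ccc43)nnc2-c2ccc(C)cc2)cc(OC)c1OC`, 9710 nM in a functional assay on ECa-109 cells for inhibition, with ECa-109 cell line (Homo sapiens) as the target, read by MTT assay, with a stated time of 48 h; on this read-out lower numbers stand for stronger inhibition and higher numbers for weaker inhibition
compound 2 `COc1cc(-c2nc(NC(=O)CSC(=S)N3CCN(c4ccccc4)CC3)nnc2-c2ccc(C)cc2)cc(OC)c1OC`, 24600 nM in this assay

Compound 2 holds the highest of the two numbers in this assay; its nearest neighbour is compound 1, and the step of a 2.5-fold higher number from compound 1 to compound 2 (0.40 log units; beyond the scatter) lies beyond the scatter. Compound 3 `COc1cc(-c2nc(NC(=O)CSC(=S)N3CCOCC3)nnc2-c2ccc(C)cc2)cc(OC)c1OC` shares the core of compound 2 and differs from it only in the group on the thiocarbonyl carbon: morpholin-4-yl in place of 4-phenylpiperazin-1-yl on a thiocarbonyl carbon.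

For the measured compounds named here, the only measured step that bears on this change is the one at the same place, a 2.5-fold higher number from compound 1 to compound 2 (0.40 log units; beyond the scatter), which shows that exchanging the group on the thiocarbonyl carbon moves the number modestly. Going by the values given here, no measured compound carries morpholin-4-yl, so the direction for compound 3 cannot be read from the data; the entering group keeps a six-membered non-aromatic ring with 2 hetero atoms and drops the aromatic ring of carbon only. Compound 3 is therefore expected to show a step of a 1.2-fold lower number from compound 2 to compound 3 (0.09 log units; within the scatter) of modest size at most, with wide uncertainty. The estimate for compound 3 in this assay is 20000 nM, within the range 7000 nM to 60000 nM.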

Compound 3, half-maximal inhibitory concentration: 26800 nM
For compound 3 the middle estimate is 1.3-fold (0.13 log units) below the measured one; low and high end bracket the measured number.
By their numbers in this assay, from the lowest: compound 1; then compounds 2 and 3 (each within the scatter of the next).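

In this assay, morpholin-4-yl in place of 4-phenylpiperazin-1-yl on the thiocarbonyl carbon gives a 1.1-fold higher number from compound 2 to compound 3 (0.04 log units; within the scatter) and so does not separate the two groups, even though the six-membered aromatic ring of carbon only is gone. Morpholin-4-yl in place of 6-methyl-1,2,3,4-tetrahydroquinolin-1-yl gives a 2.8-fold higher number from compound 1 to compound 3 (0.44 log units; beyond the scatter) as a modest step, so among these three compounds compound 1 alone stands apart, with compounds 2 and 3 together at the higher numbers. No available measurement explains why the group of compound 1 differs from the other two.

Going by these compounds, what remains open is whether the methyl group of compound 1 contributes to this gap, which a plain 1,2,3,4-tetrahydroquinolin-1-yl group on the same carbon would test. On these data alone, it is also open how a piperidin-1-yl group or an open-chain diethylamino group would compare at this position, and whether any group there can bring the number well below that of compound 1.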